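The source may report more compounds than this note shows. Statements on the series, on what has been measured and on what is new or still open speak of the compounds shown alone.

Measured so far, in a functional assay on Hs-578T cells (Homo sapiens) for inhibition, read by sulforhodamine B assay, with a stated time of 48 h; a lower number here means a stronger inhibitor of growth, a higher number a weaker inhibitor of growth:
- compound 1 `COc1cc(-c2nn(-c3cccc(NC(=O)c4ccc(Cl)c(C(F)(F)F)c4)c3)cc2-c2ccncc2)ccc1Cl`: > 32500 nM
- compound 2 `O=C(Nc1cccc(-n2cc(-c3ccncc3)c(-c3ccc(Cl)c(O)c3)n2)c1)Nc1cc(C(F)(F)F)cc(C(F)(F)F)c1`: 4080 nM
- compound 3 `COc1cc(-c2nn(-c3cccc(NC(=O)Nc4cccc(C(F)(F)F)c4)c3)cc2-c2ccncc2)ccc1Cl`: 12500 nM

Compound 1 stands at the weak end of the measured set. Its value is a limit of this assay rather than a number, as shown by the limit of > 32500 nM in this assay, at which 1 of the 3 values shown sits. Compound 3 carries a urea in place of the amide of compound 1, and the change gives an at least 2.6-fold lower number from compound 1 to compound 3 (0.41 log units; beyond the scatter). Compound 2 is also a urea, on a different core, and in this assay compound 2 gives 4080 nM.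

The compound yet to be measured is compound 4 `COc1cc(-c2nn(-c3cccc(NC(=O)Nc4ccc(Cl)c(C(F)(F)F)c4)c3)cc2-c2ccncc2)ccc1Cl`. It differs from compound 1 in one place: (4-chloro-3-(trifluoromethyl)phenyl)amino in place of 4-chloro-3-(trifluoromethyl)phenyl on a carbonyl carbon. The aryl group itself is kept; only the link from the carbonyl carbon to it changes from a direct bond to an amino bridge, making a urea. Within the data shown here, the one measured step that bears on this is the step from compound 1 to compound 3, which is the same amide-to-urea change with a different aryl. On that basis a lowering of the number, of at least modest size, is expected in this assay, though the limit of compound 1 leaves the true size open. The expected step is an at least 3.6-fold lower number from compound 1 to compound 4 (0.55 log units; beyond the scatter). For compound 4 the estimated value in this assay is 9000 nM, with a range from 2500 nM to 30000 nM.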

Compound 4, concentration for total growth inhibition: 18300 nM
Beside the measured number, compound 4's estimate is 2.0-fold (0.31 log units) below it; low and high end bracket the measured number.
By their numbers in this assay, from the lowest: compound 2; then compounds 3 and 4 (each within the scatter of the next). At a limit, above all of these: compound 1.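

In this assay, keeping the 4-chloro-3-(trifluoromethyl)phenyl group and replacing its direct bond to the carbonyl carbon with an amino bridge gives an at least 1.7-fold lower number from compound 1 to compound 4 (0.24 log units; that floor lies within the scatter). The amide-to-urea change therefore points the same way with this aryl group as with the aryl group of compound 3, but here the step cannot be shown to exceed ordinary assay variation. Compound 1 has a limit of the assay rather than a number, so the true size of this step remains unknown: the limit of > 32500 nM in this assay, at which 1 of the 4 values shown sits.

Among the ureas, chloro in place of hydrogen on an aromatic carbon gives a 1.5-fold higher number from compound 3 to compound 4 (0.17 log units; within the scatter), so this pair shows no clear effect of the chloro group on growth inhibition.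

The compounds shown leave open whether a carbamate or a sulfonamide would behave like the urea or like the amide as the link to this aryl group. They also leave open whether a fluoro or a methyl group in place of the chloro would separate from the urea pair, compound 3 and compound 4.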